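Triazole thioethers on prostate cancer cells: three limits, one unknown

The source may hold more compounds than are shown below. What is called first, only, known or untested is meant among the compounds shown, and "the series" means these compounds.

Compound 1 `COc1ccc(-n2c(SCC(=O)c3ccc(OC)c(O)c3)nnc2-c2cc(OC)c(OC)c(OC)c2)cc1` was tested in a functional assay on PC-3 cells (Homo sapiens) for inhibition, read by MTT assay, with a stated time of 48 h; a higher number here means a weaker inhibitor, a lower number a stronger inhibitor. In this assay compound 1 gives only a limit, > 60000 nM. Compound 2 `COc1ccc(-n2c(SCC(=O)c3ccc4ccccc4c3)nnc2-c2cc(OC)c(OC)c(OC)c2)cc1` differs from compound 1 by naphthalen-2-yl in place of 3-hydroxy-4-methoxyphenyl on a carbonyl carbon. In this assay compound 2 also gives only a limit, > 60000 nM. The step that the two limits leave unreadable from compound 1 to compound 2 therefore cannot be read, as stated in the limit of > 60000 nM in this assay, at which 2 of the 3 values shown sit. Compound 3 `COc1ccc(C(=O)CSc2nnc(-c3cc(OC)c(OC)c(OC)c3)n2-c2ccc(N(C)C)cc2)cc1O` differs from compound 1 by dimethylamino in place of methoxy on an aromatic carbon. In this assay compound 3 gives only a limit, > 100000 nM, which is where the limit of > 100000 nM in this assay, at which 1 of the 3 values shown sits, stands, so the step that the two limits leave unreadable from compound 1 to compound 3 is likewise unreadable. Compound 4 `COc1cc(-c2nnc(SCC(=O)c3ccc4ccccc4c3)n2-c2ccc(N(C)C)cc2)cc(OC)c1OC` is unmeasured; it differs from compound 3 by naphthalen-2-yl in place of 3-hydroxy-4-methoxyphenyl on a carbonyl carbon, the same change as from compound 1 to compound 2. Going by the values given here, since every value so far is a limit, the step of a number no higher from compound 3 to compound 4 (the limit leaves the size open) is expected to stay near zero. Compound 4 is estimated at 100000 nM, within 30000 nM to 300000 nM.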

Compound 4, half-maximal inhibitory concentration: 18100 nM
Compound 4: the middle estimate sits 5.5-fold (0.74 log units) above what was measured; the measured number lies below the stated range.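

With dimethylamino on the aromatic carbon, naphthalen-2-yl in place of 3-hydroxy-4-methoxyphenyl on a carbonyl carbon gives, in this assay, an at least 5.5-fold lower number from compound 3 to compound 4 (0.74 log units; beyond the scatter). With naphthalen-2-yl kept, dimethylamino in place of methoxy gives an at least 3.3-fold lower number from compound 2 to compound 4 (0.52 log units; beyond the scatter), so compound 4, which carries both groups, is the only compound shown with a true number. As far as these compounds go, the steps from compound 1 to compound 2 and to compound 3 have limits at both ends and cannot be read, so it remains unknown whether the naphthalen-2-yl change does the same on the core of compound 1.

A plain phenyl on the carbonyl carbon could separate the second aromatic ring from the loss of the hydroxy and methoxy groups. From the compounds shown here alone, it is also open whether an amine other than dimethylamino, such as morpholine, would serve in the same place.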